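The source may hold more compounds than are shown below. What is called first, only, known or untested is meant among the compounds shown, and "the series" means these compounds.

Measured so far in a functional assay on SKHep cells (Homo sapiens) for antiproliferative activity, read by MTT assay, with a stated time of 12 h; a lower number here means a stronger inhibitor, a higher number a weaker inhibitor:
compound 1, `COc1cc(OC)c2c(=O)cc(/C=C/c3ccncc3)oc2c1` — only a limit, > 40000 nM
compound 2, `COc1cc(OC)c2c(=O)cc(/C=C/c3ccc(OCC4CC4)cc3)oc2c1` — 22100 nM
compound 3, `COc1ccc2c(=O)cc(/C=C/c3ccc(OC(F)(F)F)cc3)oc2c1` — only a limit, > 40000 nM

All three share a closely related core. For compound 3 this assay reports only a limit, not a number. That limit is the limit of > 40000 nM in this assay, at which 2 of the 3 values shown sit, so compound 3 cannot be placed against compound 1 at all, and compound 2 alone gives an actual number, a weak one. Compound 4, `COc1ccc2c(=O)cc(/C=C/c3ccc(OC(F)(F)F)cc3)oc2c1OC`, is compound 3 with methoxy in place of hydrogen on an aromatic carbon. For the measured compounds named here, no measured pair in this set differs in exactly this way, so there is no directly comparable step to lean on. With compound 3 already sitting at the limit, the expectation is a step of no clear size in either direction, and most likely the result stays at the limit rather than becoming a number. Compound 4 is therefore expected to come out near 45000 nM, somewhere between 15000 nM and 150000 nM. The expected step is a step that the limit leaves unreadable from compound 3 to compound 4.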

Compound 4, half-maximal inhibitory concentration: 12400 nM
The estimate for compound 4 lay 3.6-fold (0.56 log units) above the measured number, and the stated range ends above it.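

In this assay, methoxy in place of hydrogen on this aromatic carbon, ortho to a methoxy group and ortho to a fused ring, gives an at least 3.2-fold lower number from compound 3 to compound 4 (0.50 log units; beyond the scatter). For the compounds shown here, this is the only single-place change in the set, so it is the first sign that this position on the shared core can affect the result. The step can only be read as a minimum, since the value for compound 3 is a limit and not a number: the limit of > 40000 nM in this assay, at which 2 of the 4 values shown sit.

Going by these compounds, it remains open whether methoxy is special here or whether another group at this position, such as an amine, a fluorine atom or a longer ethoxy chain, would give a similar step. On these data alone, it is also open whether the same change would give a similar step in a compound carrying something other than trifluoromethoxy on the far ring.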